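The source may report more compounds than this note shows. Statements on the series, on what has been measured and on what is new or still open speak of the compounds shown alone.

Measured compounds:
- compound 1 `CCCc1nc(-c2ccccc2)c(CNCCCN2CCN(c3cccc(F)c3)CC2)o1` — 3030 nM
- compound 2 `CCCc1nc(-c2ccccc2)c(CNCCCN2CCN(c3cccc(C)c3C)CC2)o1` — 1780 nM
- compound 3 `CCCc1nc(-c2ccccc2)c(CNCCN2CCN(c3cccc(C)c3C)CC2)o1` — 1710 nM

In an assay on HEK293 cells for inhibition of Voltage-dependent T-type calcium channel subunit alpha-1G (Homo sapiens), read by patch clamp (a higher number here means a weaker inhibitor, a lower number a stronger inhibitor), compound 2 stands second highest of the three numbers. Compound 3, the nearest, and compound 1, the furthest, both lie within the scatter of compound 2, so the three measured values cannot be ranked against each other.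

Compound 4 `CCCc1nc(-c2ccccc2)c(CNCCCN2CCN(c3ccc(C)c(C)c3)CC2)o1` has not been measured. It differs from compound 2 by 3,4-dimethylphenyl in place of 2,3-dimethylphenyl on an amine nitrogen in a ring; the two compounds share every atom, joined differently.

Within the data shown here, only one measured step touches the group on the ring nitrogen: a 1.7-fold lower number from compound 1 to compound 2 (0.23 log units; within the scatter). That step exchanged one aryl group for another and stayed within the scatter. Among the measured compounds shown here, no measured pair moves a methyl from one position of the aryl ring to another, so nothing directly tells how this change behaves. On this basis, no step beyond the scatter in this assay is expected from compound 2 to compound 4; the expected step is a 1.0-fold higher number from compound 2 to compound 4 (0.00 log units; within the scatter).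

For compound 4 the expected value in this assay is 1800 nM, with a range from 700 nM to 4500 nM.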

Compound 4, half-maximal inhibitory concentration: 3020 nM
For compound 4 the middle estimate is 1.7-fold (0.22 log units) below the measured one; the measured number falls inside the stated range.
By their numbers in this assay, from the lowest: compounds 3, 2, 4 and 1 (each within the scatter of the next).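

Working notes on the group on the ring nitrogen: in this assay, the first pair with the same atoms at this position, 3,4-dimethylphenyl in place of 2,3-dimethylphenyl gives a 1.7-fold higher number from compound 2 to compound 4 (0.23 log units; within the scatter). The same group in place of 3-fluorophenyl gives a 1.0-fold lower number from compound 1 to compound 4 (0.00 log units; within the scatter). Across these three aryl groups on the shared core, neither rearranging the two methyl groups nor exchanging them for the fluorine produces a step beyond the scatter.

Still open, on these data alone, is whether a benzyl group on this nitrogen, or a carboxylic acid on the aryl ring, would step beyond the scatter. Also open, as far as these compounds go, is whether 3,4-dimethylphenyl would behave the same way on the shorter chain of compound 3. No supporting evidence bears on this result.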